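This account rests on a few compounds, and the source may have more. Where it says the series, first, only, none or still open, it means among the compounds named here.

Compound 2 `COc1cc(-c2ccnc3cc(-c4ccc(N(C)C)cc4)nn23)cc(OC)c1OC` gives in a functional assay on A549 cells (Homo sapiens) for inhibition, read by CCK-8 assay, with a stated time of 48 h (on this read-out lower numbers stand for stronger inhibition and higher numbers for weaker inhibition), a value of 1100 nM. For the measured compounds named here, on the two numbers so far compound 2 stands at the top, but compound 1 `COc1cc(-c2ccnc3cc(-c4ccc5ccn(C)c5c4)nn23)cc(OC)c1OC`, at 829 nM, lies within the scatter of it, so no order between the two is claimed. Going by the values given here, the single measured step, a 1.3-fold higher number from compound 1 to compound 2 (0.12 log units; within the scatter), stayed within the scatter. Compound 3 `COc1cc(-c2ccnc3cc(-c4ccc5cnn(C)c5c4)nn23)cc(OC)c1OC` differs from compound 2 by 1-methyl-1H-indazol-6-yl in place of 4-(dimethylamino)phenyl on an aromatic carbon. The entering 1-methyl-1H-indazol-6-yl differs from the 1-methyl-1H-indol-6-yl of compound 1 only in the five-membered ring, so the step from compound 2 to compound 3 is nearly the reverse of the step already measured; a step within the scatter is expected, if anything toward a lower number. For compound 3 a value of 850 nM is estimated, with a range of 400 nM to 1800 nM. This estimate means an expected step of a 1.3-fold lower number from compound 2 to compound 3 (0.11 log units; within the scatter).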

Compound 3, half-maximal inhibitory concentration: 233 nM
Compound 3: the middle estimate sits 3.6-fold (0.56 log units) above what was measured; measured number outside the range, below it.
By their numbers in this assay, from the lowest: compound 3; then compounds 1 and 2 (each within the scatter of the next).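

In this assay, for the compounds shown here, the aromatic carbon of the shared core proves sensitive to the group it carries: 1-methyl-1H-indazol-6-yl in place of 4-(dimethylamino)phenyl gives a 4.7-fold lower number from compound 2 to compound 3 (0.67 log units; beyond the scatter) and is the first step beyond the scatter. The change confined to the five-membered ring also counts, as 1-methyl-1H-indazol-6-yl in place of 1-methyl-1H-indol-6-yl gives a 3.6-fold lower number from compound 1 to compound 3 (0.55 log units; beyond the scatter) even though the two groups are otherwise alike. No supporting data bear on the origin of these differences.

Still open, from the compounds shown here alone, is whether the added ring nitrogen of 1-methyl-1H-indazol-6-yl carries the effect alone or depends on the methyl group beside the rest of that ring system. An ethyl group or hydrogen in place of that methyl, or an amine on the six-membered ring, would test how far the trend extends.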